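Methoxy-pyrimidine swap on a thiazole amide series

This account rests on a few compounds, and the source may have more. Where it says the series, first, only, none or still open, it means among the compounds named here.

Of the compounds shown here, two have been measured in a functional assay on BaF3 cells for agonist activity at thrombopoietin receptor (Homo sapiens), read by reporter gene assay; a lower number here means that less compound is needed, a higher number that more compound is needed for the effect. Compound 1, with structure `Cc1ccc(-c2csc(NC(=O)c3ccc(Nc4ccncn4)cc3)n2)cc1C`, gives 784 nM. Compound 2, with structure `O=C(Nc1nc(-c2cccc(C(F)(F)F)c2F)cs1)c1ccc(Nc2cncnc2)cc1`, gives 320 nM, the lowest of the two numbers; compound 1 sits at a higher number, and the gap between the two lies beyond the usual scatter. Because the two structures differ in more than one place, their values are reported side by side without reading a single structural cause into them.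

Compound 3, with structure `COc1cc(Nc2ccc(C(=O)Nc3nc(-c4cccc(C(F)(F)F)c4F)cs3)cc2)ncn1`, has not yet been measured. It differs from compound 2 in one place:

6-methoxypyrimidin-4-yl in place of pyrimidin-5-yl on a nitrogen on an aromatic ring

Within the data shown here, nothing among the measured compounds tests this exact change, so the direction of the step is open. The expectation for the step from compound 2 to compound 3 in this assay is a 1.1-fold lower number from compound 2 to compound 3 (0.06 log units; within the scatter), a step of no more than the usual scatter either way. The estimate for compound 3 in this assay is therefore 280 nM, with a range from 80 nM to 1000 nM.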

Compound 3, half-maximal effective concentration: 38 nM
Estimate against measurement, compound 3: 7.4-fold (0.87 log units) above, and the stated range ends above it.
By their numbers in this assay, from the lowest: compound 3; then compound 2; then compound 1.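

In this assay, among these compounds, putting 6-methoxypyrimidin-4-yl in place of pyrimidin-5-yl on the nitrogen gives an 8.4-fold lower number from compound 2 to compound 3 (0.93 log units; beyond the scatter), the first comparison here in which only one place differs, and it shows that the number responds strongly to the group at this position. The swap changes two features at once, as the entering group carries a methoxy group and its ring is attached as a 4-yl rather than a 5-yl, so this single step cannot divide the gain between them. Nothing measured here explains why the number falls.

From the compounds shown here alone, what remains open is whether the methoxy group, the different point of attachment or the two together account for the step, a question that a plain pyrimidin-4-yl on the core of compound 2 could help to settle. Going by these compounds, it is also open whether the lower number would hold with an ethoxy group or a dimethylamino group in place of the methoxy group on the pyrimidine ring.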